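Acetyl for Methanesulfonamido on a Benzamide Core

The source may hold more compounds than are shown below. What is called first, only, known or untested is meant among the compounds shown, and "the series" means these compounds.

For the measured compounds named here, compound 1 `CC(C)(C)c1ccc(C(=O)NCc2ccc(NS(C)(=O)=O)cc2)cc1` is one of two compounds measured so far in an assay on HeLa cells with Bile acid receptor (Homo sapiens) as the target, read by a luciferase reporter, with a stated time of 24 h; on this read-out higher numbers stand for an effect only at larger amounts of compound and lower numbers for an effect already at smaller amounts. Compound 1 gives 44 nM, the higher of the two numbers. Going by the values given here, the nearest is compound 2 `CC(C)(C)c1ccc(C(=O)NCc2ccc(C(=O)O)c(Cl)c2)cc1`, which in this assay gives 8.8 nM, a difference beyond the usual scatter; no single-change step between the two compounds is recorded.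

Compound 3 `CC(=O)c1ccc(CNC(=O)c2ccc(C(C)(C)C)cc2)cc1` has not yet been measured. It differs from compound 1 in one place: acetyl in place of methanesulfonamido on an aromatic carbon. Among the compounds with values here, no measured pair shows such a change, so the outcome rests on the two values above alone. A step of moderate size is expected, most likely toward a higher number, since the hydrogen-bond donor leaves with the methanesulfonamido group. Compound 3 is thus estimated to give 90 nM in this assay, with a range from 25 nM to 320 nM, meaning an expected step of a 2.0-fold higher number from compound 1 to compound 3 (0.31 log units; beyond the scatter).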

Compound 3, half-maximal effective concentration: 100 nM
Estimate against measurement, compound 3: 1.1-fold (0.05 log units) below; low and high end bracket the measured number.
By their numbers in this assay, from the lowest: compound 2; then compound 1; then compound 3.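

In this assay, putting acetyl in place of methanesulfonamido on this aromatic carbon, para to a large group, gives a 2.3-fold higher number from compound 1 to compound 3 (0.36 log units; beyond the scatter), which shows that this position responds to a change of group, though only modestly on this single step. Even with no hydrogen-bond donor in the entering group, compound 3 still gives a finite value of 100 nM in this assay, so a donor at this place is not required for a read-out in this assay. No measurement at hand separates the loss of the donor from the change in group size, and nothing available accounts for the step.

The compounds shown leave open how an amine or a methyl ester at this place would compare with acetyl. Compound 2 differs from compound 1 and from compound 3 in more than one place, so its carboxylic acid cannot be set against either group on its own.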